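Adding a Second Ethyl to the Amide Nitrogen

The source may report more compounds than this note shows. Statements on the series, on what has been measured and on what is new or still open speak of the compounds shown alone.

Compound 1 `CCNC(=O)/C=C(C)/C=C/CC(C)CCCC(C)(C)OC` and compound 2 `CCN(CC)C(=O)/C=C(C)/C=C/CC(C)CCCC(C)(C)OC` differ in one place, (ethyl in place of hydrogen on an amide-type nitrogen). In a physicochemical assay for lipophilicity (a higher number here means a more lipophilic compound, a lower number a more polar compound), compound 1 gives 4.04, while compound 2 gives 4.82, a step of a number 0.78 log units higher from compound 1 to compound 2 (beyond the scatter). Compound 3 `CCNC(=O)/C=C(C)/C=C/CC(C)CCC=C(C)C` carries a different core; against compound 1 the difference is 2-methylprop-1-en-1-yl in place of 2-methoxy-2-methylpropyl on a saturated chain carbon, four bonds along the chain from a double-bonded chain carbon, and in this assay compound 3 gives 4.69, a step of a number 0.65 log units higher from compound 1 to compound 3 (beyond the scatter). Compound 4 `CCN(CC)C(=O)/C=C(C)/C=C/CC(C)CCC=C(C)C` has not yet been measured. It stands to compound 3 as compound 2 stands to compound 1, the change being (ethyl in place of hydrogen on an amide-type nitrogen), at a place described in the same words both times, so it is the same change. Because the step of a number 0.78 log units higher from compound 1 to compound 2 (beyond the scatter) was measured for this change on the core of compound 1, a step of similar size is expected here, a number 0.78 log units higher from compound 3 to compound 4 (beyond the scatter). Compound 4 is therefore estimated to give 5.47 in this assay.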

Compound 4, partition coefficient: 5.47
For compound 4 middle estimate and measured number coincide at the digits printed; low and high end bracket the measured number.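

In this assay, ethyl in place of hydrogen on an amide-type nitrogen gives a number 0.78 log units higher from compound 3 to compound 4 (beyond the scatter), matching a number 0.78 log units higher from compound 1 to compound 2 (beyond the scatter), while the other change gives a number 0.65 log units higher from compound 2 to compound 4 (beyond the scatter), matching a number 0.65 log units higher from compound 1 to compound 3 (beyond the scatter), and so across these four compounds each change has the same size on both cores. This shows that the step carried over between these two cores, but it does not show that it would carry over to any other core. No measurement shown here explains the size of either step.

Still open, as far as these compounds go, is whether propyl in place of ethyl on the amide-type nitrogen would continue this trend. Also open, from the compounds shown here alone, is how a carboxylic acid at the chain end would behave.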